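A few compounds are considered here, and "the series" means these few. Any claim that something is new, unique, unknown or untested is made for them only; others in the source may bear on it.

Measured so far:
compound 1 `COc1ccc2c(=O)c(/C=C/C(=O)Nc3ccccc3Cl)coc2c1` — 1010000 nM
compound 2 `O=C(/C=C/c1coc2cc(O)ccc2c1=O)NCc1ccc(F)cc1` — 357000 nM

In an ADME assay on HepG2 2.2.15 cells (Homo sapiens) for cytotoxicity, read by MTT assay, with stated times of 48 h and 9 days (on this read-out lower numbers stand for higher toxicity in this test and higher numbers for lower toxicity in this test), compound 1 gives the higher of the two numbers; compound 2 gives a lower number, and that gap lies beyond the usual scatter. Compound 3 `COc1ccc2c(=O)c(/C=C/C(=O)Nc3ccc(Cl)cc3)coc2c1` differs from compound 1 only by 4-chlorophenyl in place of 2-chlorophenyl on an amide-type nitrogen. For the measured compounds named here, no measured pair shows what moving a chlorine around that ring does to this assay, so the step is expected to be small, likely none beyond the scatter, in either direction. Compound 3 is therefore expected to give about 800000 nM, within a range from 300000 nM to 2000000 nM. The expected step is a 1.3-fold lower number from compound 1 to compound 3 (0.10 log units; within the scatter).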

Compound 3, half-maximal cytotoxic concentration: 272000 nM
For compound 3 the middle estimate is 2.9-fold (0.47 log units) above the measured one, outside the stated range (below it).
By their numbers in this assay, from the lowest: compounds 3 and 2 (each within the scatter of the next); then compound 1.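

In this assay, the position of the chlorine on this ring matters: 4-chlorophenyl in place of 2-chlorophenyl on the amide-type nitrogen gives a 3.7-fold lower number from compound 1 to compound 3 (0.57 log units; beyond the scatter), a modest step. The two compounds have the same atoms, joined differently, so moving one chlorine is enough to make the compound more toxic in this test. The compounds shown leave open whether an amine or a carboxylic acid in place of that chlorine would shift the number further. Nothing available explains the step itself.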